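The compounds below may be only part of what the source reports. "The series", "measured", "known", "first", "only" and "open" are said of these compounds alone.

Measured so far in a functional assay (Oryctolagus cuniculus) for antagonist activity at platelet-activating factor receptor (Cavia porcellus); on this read-out lower numbers stand for stronger inhibition and higher numbers for weaker inhibition:
- compound 1, `O=C(c1ccn2c1CSC2c1cccnc1)c1c[nH]c2cccc(O)c12`: compound 1 gives 327 nM
- compound 2, `CN(C)C(=O)n1cc(C(=O)c2ccn3c2CSC3c2cccnc2)c2ccc(OCc3ccccc3)cc21`: compound 2 gives 17 nM

Of the two compounds measured, compound 2 stands at the lower number; its nearest neighbour is compound 1, whose higher number lies beyond the usual scatter, so compound 2 shows the stronger inhibition of the pair in this assay. For the measured compounds named here, no pair of measured compounds differs in only one place, so no single structural step has yet been followed by a measured value.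

The step now taken goes from compound 2 to compound 3, `CN(C)C(=O)n1cc(C(=O)c2ccn3c2CSC3c2cccnc2)c2ccc(-c3ccccc3)cc21`. The change is phenyl in place of benzyloxy on an aromatic carbon. The benzyloxy of compound 2 gives way to phenyl, sitting on the same aromatic carbon of the fused two-ring system.

Going by the values given here, no measured step shows what this change does here. The account therefore expects a modest move toward weaker inhibition, a step of a 2.4-fold higher number from compound 2 to compound 3 (0.37 log units; beyond the scatter) in this assay, though a result within the scatter of compound 2 is also plausible. Compound 3 is estimated at 40 nM, with a range from 10 nM to 160 nM.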

Compound 3, inhibition constant: 23 nM
Compound 3: middle estimate off by 1.7-fold (0.24 log units), on the high side, within the range that was stated.
By their numbers in this assay, from the lowest: compounds 2 and 3 (each within the scatter of the next); then compound 1.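

In this assay, putting phenyl in place of benzyloxy on this aromatic carbon of the fused system of two rings gives a 1.4-fold higher number from compound 2 to compound 3 (0.13 log units; within the scatter), so compounds 2 and 3 cannot be told apart on this read-out. This single pair shows that the position can carry either group without a step beyond the scatter, even though the entering phenyl has fewer heavy atoms than benzyloxy, no oxygen and no hydrogen-bond acceptor. Nothing measured beyond these values bears on why the two compounds read alike.

The compounds shown leave open whether this carbon accepts groups other than an unsubstituted benzene ring carried directly or through the benzyloxy link, such as an amine, a carboxylic acid or a longer alkyl chain, or plain hydrogen in place of any group. Compound 1 differs from compounds 2 and 3 in more than one place, so it cannot say how much of the inhibition seen in those two depends on the group at this position.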